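Extending the formylamino acyl group of a dihydropyridazinone

This account rests on a few compounds, and the source may have more. Where it says the series, first, only, none or still open, it means among the compounds named here.

Compound 1 has the structure `O=CNc1ccc(C2=NNC(=O)CC2)cc1`. In a functional assay for inhibition, with Homo sapiens as the target (on this read-out lower numbers stand for an effect already at smaller amounts and higher numbers for an effect only at larger amounts of compound), compound 1 gives 3.74 ug/mL, the lower of the two numbers measured here. Compound 2, whose structure is `CC(=O)Nc1ccc(C2=NNC(=O)C(C)C2)cc1`, differs in more than one place and is not a single step from compound 1; in this assay compound 2 gives 46.4 ug/mL, which lies beyond the scatter from compound 1. Compound 3 is the unmeasured compound `O=C1CCC(c2ccc(NC(=O)CCCl)cc2)=NN1`. Compared with compound 1 it shows (2-chloroethyl in place of hydrogen on a carbonyl carbon), that is, formyl becomes (2-chloroethyl)carbonyl on the amide. For the measured compounds named here, no single-point step has been measured, so the size of this change is uncertain; the author expects a modest weakening beyond the scatter in this assay, as a 2.4-fold higher number from compound 1 to compound 3 (0.38 log units; beyond the scatter). Compound 3 is therefore estimated at 9 ug/mL, with a range from 2.5 ug/mL to 30 ug/mL.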

Compound 3, half-maximal effective concentration: 0.98 ug/mL
Beside the measured number, compound 3's estimate is 9.2-fold (0.96 log units) above it; the measured number lies below the stated range.
By their numbers in this assay, from the lowest: compound 3; then compound 1; then compound 2.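

In this assay, for the compounds shown here, the change of formyl to (2-chloroethyl)carbonyl on the amide gives a 3.8-fold lower number from compound 1 to compound 3 (0.58 log units; beyond the scatter) and is the first step that can be read in a single place. It shows that this position, a carbonyl carbon whose other neighbour is the amide-type nitrogen, accepts 2-chloroethyl in place of hydrogen, and that the number moves down rather than up with this change. No measurement at hand bears on why the number moves this way.

The compounds shown leave open whether the step belongs to the chlorine or to the carbon chain, a question that a plain ethyl group at the same carbonyl carbon would address. They also leave open how a longer chain, or an amine in place of the chlorine, would read.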